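Halogen swap on the ester-bearing core of compound 1

A few compounds are considered here, and "the series" means these few. Any claim that something is new, unique, unknown or untested is made for them only; others in the source may bear on it.

Measured so far:
- compound 1 `CCOC(=O)Cn1cnc2c(Br)ncnc21`: 23500 nM
- compound 2 `CCOC(=O)Cn1cc(F)c(=O)[nH]c1=O`: 24600 nM

Both compounds were tested in a functional assay on HCT-116 cells (Homo sapiens) for antiproliferative activity, read by colorimetric assay and sulforhodamine B assay, with a stated time of 3 days; a lower number here means a stronger inhibitor, a higher number a weaker inhibitor. Compound 1 gives 23500 nM and has the lowest of the two numbers, but its nearest neighbour is compound 2 at 24600 nM, which is within the scatter, so the two cannot be told apart on these data. Within the data shown here, no step between measured compounds that differ in one place is available.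

Compound 3 `CCOC(=O)Cn1cnc2c(Cl)ncnc21` is not yet measured. It differs from compound 1 by chloro in place of bromo on an aromatic carbon, on an aromatic carbon of the shared core, next to the ring nitrogen. Among the measured compounds shown here, with no comparable step among the measured compounds, the expectation for compound 3 rests on the small size of the change alone; the step of a 1.1-fold higher number from compound 1 to compound 3 (0.03 log units; within the scatter) is expected to be none beyond the scatter. Compound 3 is therefore estimated at 25000 nM, in the range 10000 nM to 60000 nM.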

Compound 3, half-maximal inhibitory concentration: 5270 nM
For compound 3 the middle estimate is 4.7-fold (0.68 log units) above the measured one; the measured number lies below the stated range.
By their numbers in this assay, from the lowest: compound 3; then compounds 1 and 2 (each within the scatter of the next).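

In this assay, among these compounds, the series now has a first step that changes one place only: with chloro in place of bromo on an aromatic carbon of the shared core, next to the ring nitrogen, it shows a 4.5-fold lower number from compound 1 to compound 3 (0.65 log units; beyond the scatter) and so marks this position as sensitive to which halogen it carries. The change is confined to that one halogen, with the rest of the core and the ester side chain the same in both compounds. No measured property of the two halogens is available to account for the step.

As far as these compounds go, a single step between two halogens sets no pattern, so it remains open how fluoro, iodo or an amine at this position would compare. From the compounds shown here alone, the ester side chain also remains open, including how a carboxylic acid or a longer chain there would compare.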